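Adding Bromo to an Amide-Bearing Core

The source may hold more compounds than are shown below. What is called first, only, known or untested is meant among the compounds shown, and "the series" means these compounds.

Measured in a functional assay on the whole organism for inhibition, with Cavia porcellus as the target; a lower number here means that less compound is needed, a higher number that more compound is needed for the effect:
Compound 1 `Brc1cncc2nccn12`: 18 nM
Compound 2 `NC(=O)c1cn2ccncc2n1`: > 56 nM

Compound 2 stands at > 56 nM, and this value is a limit of the assay, not a number. Compound 3 `NC(=O)c1cn2c(Br)cncc2n1` has not yet been measured. It keeps the amide of compound 2 and carries bromo in place of hydrogen on an aromatic carbon.

Going by the values given here, no measured pair shows this change on its own, so the expectation rests on very little. Compound 1, which also carries a bromo group, gives 18 nM in this assay, and this suggests that the bromo compound may need less compound for the effect. The expected step is an at least 1.8-fold lower number from compound 2 to compound 3 (0.27 log units; that floor lies within the scatter), a moderate move toward a lower number, though its starting point is only a limit. The estimate for compound 3 is 30 nM, with an expected range of 8 nM to 120 nM.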

Compound 3, concentration for half-maximal effect: 38 nM
Compound 3: the middle estimate sits 1.3-fold (0.10 log units) below what was measured; measured number inside the range.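

Going by these compounds alone, for the first time, bromo and the amide stand together on one core, and in this assay bromo in place of hydrogen on this aromatic carbon, next to the ring nitrogen, gives an at least 1.4-fold lower number from compound 2 to compound 3 (0.16 log units; that floor lies within the scatter). That step is only a floor, and its true size stays unknown, because compound 2 has a limit and not a number: the limit of > 56 nM in this assay, at which 1 of the 3 values shown sits.

Read from the other side, adding the amide to the bromo compound gives a 2.1-fold higher number from compound 1 to compound 3 (0.32 log units; beyond the scatter), so this change brings a modest rise in the amount needed.

Going by these compounds, whether bromo in particular matters at this carbon remains open, since a chlorine atom, a methyl group or an amine could do the same or differ. On these data alone, how the amide compares with a carboxylic acid or a nitrile in its place also remains open.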